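The compounds below may be only part of what the source reports. "The series", "measured", "known", "first", "only" and "open" are said of these compounds alone.

Compound 3 `C#CCN(c1nc(-c2ccc(Br)cc2)no1)C1CCCCC1` gives 15.7 ug/mL in an ADME assay on RAW264.7 cells (Mus musculus) for cytotoxicity, read by MTT assay, with a stated time of 48 h (on this read-out higher numbers stand for lower toxicity in this test and lower numbers for higher toxicity in this test), the lowest of the three numbers shown. Compound 1 `C#CCN(c1nc(-c2cccc(C)c2)no1)C1CCCCC1` gives 25.9 ug/mL, and the change a 1.6-fold lower number from compound 1 to compound 3 (0.22 log units; within the scatter) stays within the scatter. Compound 2 `C#CCOc1ccc(-c2noc(N(CC#C)C3CCCCC3)n2)cc1` gives 101 ug/mL, and the change a 6.4-fold lower number from compound 2 to compound 3 (0.81 log units; beyond the scatter) goes beyond it. Compound 4 `C#CCN(c1nc(-c2ccc(F)cc2)no1)C1CCCCC1` differs from compound 3 by fluoro in place of bromo on an aromatic carbon. Among the compounds with values here, both measured steps touch the same aromatic carbon region, and the one that moved the number beyond the scatter involved a larger group leaving; a halogen-for-halogen swap on that carbon has no direct precedent here, so the expected step of a 1.6-fold higher number from compound 3 to compound 4 (0.20 log units; within the scatter) is small. Compound 4 is therefore estimated at 25 ug/mL in this assay, with a range from 10 ug/mL to 60 ug/mL.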

Compound 4, half-maximal cytotoxic concentration: 20.9 ug/mL
Beside the measured number, compound 4's estimate is 1.2-fold (0.08 log units) above it; low and high end bracket the measured number.
By their numbers in this assay, from the lowest: compounds 3, 4 and 1 (each within the scatter of the next); then compound 2.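

Fluoro in place of bromo on this aromatic carbon (a 1.3-fold higher number from compound 3 to compound 4 (0.12 log units; within the scatter)) shows that, in this assay, exchanging one halogen for the other at this position stays within the scatter. The result also extends the earlier picture: the 4-fluorophenyl group stays within the scatter of the 3-methylphenyl group (a 1.2-fold lower number from compound 1 to compound 4 (0.09 log units; within the scatter)), while fluoro, like bromo, lies beyond it from propargyloxy (a 4.8-fold lower number from compound 2 to compound 4 (0.68 log units; beyond the scatter)). Nothing given here explains these numbers. From the compounds shown here alone, whether an amine, a carboxylic acid or a longer alkoxy chain on this carbon would stay with the halogens or move toward compound 2 remains open.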